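Removing the Trifluoromethyl Group from a Benzothiazole Amide Series

This account rests on a few compounds, and the source may have more. Where it says the series, first, only, none or still open, it means among the compounds named here.

Of the compounds shown here, three from this series have been tested in an ADME assay on RAW264.7 cells (Mus musculus) for cytotoxicity, read by MTT assay, with a stated time of 72 h, tested at 50 ug/mL; a lower number here means less inhibition, a higher number more inhibition at the concentration tested (going by the name of the read-out). Compound 1, `O=C(c1nc2cc(Cl)ccc2s1)N1CCN(c2cnccn2)CC1`, gives 54.9%. Compound 2, `COc1ccccc1N1CCN(C(=O)c2nc3ccccc3s2)CC1`, gives 53.4%. Compound 3, `O=C(c1nc2cc(C(F)(F)F)ccc2s1)N1CCN(c2cnccn2)CC1`, gives 28.1%, the lowest of the three numbers; its nearest neighbour is compound 2, which lies beyond the scatter above it, and compound 1 lies further still.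

The next compound, compound 4, is `O=C(c1nc2ccccc2s1)N1CCN(c2cnccn2)CC1`. It differs from compound 3 in one place: hydrogen in place of trifluoromethyl on an aromatic carbon.

Going by the values given here, only one measured step bears on this change. The step of a number 26.8 percentage points lower from compound 1 to compound 3 (beyond the scatter) shows that putting trifluoromethyl in place of chloro lowered the inhibition in this assay by a modest but clear amount. Compound 4 removes that trifluoromethyl group again, this time leaving hydrogen. Compound 2 also carries hydrogen at the corresponding carbon, although it differs elsewhere, and shows a value in the same region as compound 1. A return toward the higher values therefore seems the more likely outcome, though the two reference points do not settle how far it goes.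

For compound 4 the expected result in this assay is 50%, with a range from 35% to 65%. This estimate corresponds to an expected step of a number 21.9 percentage points higher from compound 3 to compound 4 (beyond the scatter).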

Compound 4, a percentage reported as inhibition, at one concentration (the size of the read-out at that concentration, not a potency): 65.3%
Estimate against measurement, compound 4: 15.3 percentage points below; the measured number lies above the stated range.
By their numbers in this assay, from the lowest: compound 3; then compounds 2 and 1 (each within the scatter of the next); then compound 4.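

Hydrogen at this aromatic carbon does more than reverse the fall seen with trifluoromethyl: read in this assay the change gives a number 37.2 percentage points higher from compound 3 to compound 4 (beyond the scatter) and so exceeds the earlier drop, a number 26.8 percentage points lower from compound 1 to compound 3 (beyond the scatter). Hydrogen also separates from chloro, with a number 10.4 percentage points higher from compound 1 to compound 4 (beyond the scatter), so the three groups at this carbon now fall in a clear order, with trifluoromethyl lowest, chloro in the middle and hydrogen highest, and compound 4 stands above every other compound shown. The other end of the molecule matters too, though the shift there is smaller: pyrazin-2-yl in place of 2-methoxyphenyl on the ring amine nitrogen gives a number 11.9 percentage points higher from compound 2 to compound 4 (beyond the scatter).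

Nothing among these results explains why the number moves in this way with either change. On these data alone, it remains open whether an amine, a methoxy group or a carboxylic acid at this aromatic carbon would sit with hydrogen or with trifluoromethyl, and whether the same order of groups would hold with 2-methoxyphenyl on the ring nitrogen, since the three groups have been compared only with pyrazin-2-yl there.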